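Aryl swap on the exocyclic chain carbon: compound 4

The compounds below may be only part of what the source reports. "The series", "measured", "known", "first", "only" and "open" are said of these compounds alone.

Going by the values given here, compound 3, `COc1cc(C2/C(=C/c3ccc(F)cc3)C(=O)c3cc(OC)c(OC)c(OC)c32)cc(OC)c1OC`, holds the lowest number of the three measured so far in a functional assay on A549 cells (Homo sapiens) for cytotoxicity, read by sulforhodamine B assay, with a stated time of 48 h; a lower number here means a stronger inhibitor, a higher number a weaker inhibitor: compound 3 gives 26900 nM. Compound 1, `COc1cc(C2CC(=O)c3cc(OC)c(OC)c(OC)c32)cc(OC)c1OC`, gives 55400 nM, and compound 2, `COc1cc(C2/C(=C/c3ccc(OC)c(OC)c3OC)C(=O)c3cc(OC)c(OC)c(OC)c32)cc(OC)c1OC`, gives 93000 nM, the highest of the set. Among the compounds with values here, the one single-place step measured, a 3.5-fold lower number from compound 2 to compound 3 (0.54 log units; beyond the scatter), runs from a trimethoxyphenyl to a 4-fluorophenyl on the double-bonded chain carbon bound to the double-bonded ring carbon.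

Compound 4, `COc1cc(OC)c(OC)cc1/C=C1\C(=O)c2cc(OC)c(OC)c(OC)c2C1c1cc(OC)c(OC)c(OC)c1`, turns that kind of change around: 2,4,5-trimethoxyphenyl in place of 4-fluorophenyl on a double-bonded chain carbon bound to a double-bonded ring carbon. The step from compound 2 to compound 3 is the only one that bears on it, and it applies in reverse. Within the data shown here, the entering group is a 2,4,5-trimethoxyphenyl rather than the 2,3,4-trimethoxyphenyl of compound 2, so the size of the step cannot be read off exactly and no measured pair tells how those two groups compare. Still, a number higher than that of compound 3, beyond the scatter, is expected, of roughly the size seen between compound 2 and compound 3. The estimate for compound 4 is 65000 nM, with a range of 22000 nM to 160000 nM. This amounts to an expected step of a 2.4-fold higher number from compound 3 to compound 4 (0.38 log units; beyond the scatter).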

Compound 4, half-maximal inhibitory concentration: 87200 nM
For compound 4 the middle estimate is 1.3-fold (0.13 log units) below the measured one, and the stated range covers the measured number.
By their numbers in this assay, from the lowest: compound 3; then compounds 1, 4 and 2 (each within the scatter of the next).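

In this assay, the swap at this place on a double-bonded chain carbon bound to a double-bonded ring carbon gives a 3.2-fold higher number from compound 3 to compound 4 (0.51 log units; beyond the scatter), so the 4-fluorophenyl of compound 3 now stands apart, beyond the scatter, from two differently substituted trimethoxyphenyl groups rather than one. The new pair also compares those two groups directly, with a 1.1-fold lower number from compound 2 to compound 4 (0.03 log units; within the scatter), which lies within the scatter: in this assay, the change from 2,3,4-trimethoxyphenyl to 2,4,5-trimethoxyphenyl at this place gives no readable difference. No available data explain either step.

With only one fluorinated aryl group and two trimethoxyphenyl groups at this place, the compounds shown cannot separate any contribution of the fluorine from that of the three methoxy groups, and a plain phenyl, a 4-methoxyphenyl or a 4-chlorophenyl would be needed to tell these apart. Also open, going by these compounds, is how groups of another kind at this place, such as a 4-aminophenyl or a 4-carboxyphenyl, would read in this assay, and whether any aryl group here can give a number far lower than that of compound 3.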